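This account rests on a few compounds, and the source may have more. Where it says the series, first, only, none or still open, it means among the compounds named here.

Compound 1, `O=c1cc(Cn2cc(C3CC3)nn2)c2ccc(O)cc2o1`: > 100000 nM
Compound 2, `O=c1cc(Cn2cc(CCO)nn2)c2ccc(O)cc2o1`: > 100000 nM
Compound 3, `O=c1cc(Cn2cc(CCCO)nn2)c2ccc(O)cc2o1`: > 100000 nM

Each of these three readings in a functional assay on CFPAC-1 cells (Homo sapiens) for inhibition, read by MTT assay, with a stated time of 72 h (a lower number here means a stronger inhibitor, a higher number a weaker inhibitor), is a limit of the assay and not a number. Compound 2 stands at that limit, and its value says nothing more than that it is one. The same holds for compound 1 and for compound 3, so that all three sit at the same boundary (the limit of > 100000 nM in this assay, at which 3 of the 3 values shown sit).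

The steps among the measured compounds are therefore unreadable: a step that the two limits leave unreadable from compound 1 to compound 2, a step that the two limits leave unreadable from compound 1 to compound 3 and a step that the two limits leave unreadable from compound 2 to compound 3 cannot be sized, since both ends of each lie at the limit.

Compound 4, `CC(C)(C)c1cn(Cc2cc(=O)oc3cc(O)ccc23)nn1`, is not yet measured. It differs from compound 2 by tert-butyl in place of 2-hydroxyethyl on an aromatic carbon. The measured steps that bear on this change are those exchanging the group on the same aromatic carbon, and none of them gave a readable size. No direction of movement in this assay can be taken from them, and the expectation for compound 4 is that it will again rest at the limit, with a step that the limit leaves unreadable from compound 2 to compound 4 expected to be unreadable. Compound 4 is estimated at 150000 nM, with a range from 50000 nM to 500000 nM.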

Compound 4, half-maximal inhibitory concentration: > 100000 nM
Compound 4 ended at the assay's limit; the forecaster's own chance of this, stated with the estimate: 85%; the middle value lies beyond the limit too.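

For the compounds shown here, no step from compound 1, compound 2 or compound 3 to compound 4 can be read, since all four compounds rest at one boundary in this assay: the limit of > 100000 nM in this assay, at which 4 of the 4 values shown sit. The compounds shown leave open whether any group on this aromatic carbon would give a readable value.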